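Acetyl in Place of Trifluoromethoxy: An Expected Step

The source may hold more compounds than are shown below. What is called first, only, known or untested is meant among the compounds shown, and "the series" means these compounds.

Of the compounds shown here, three sharing one core have been measured in an ADME assay on WI-38 cells (Homo sapiens) for cytotoxicity, read by MTT assay, with a stated time of 72 h; a lower number here means a stronger inhibitor, a higher number a weaker inhibitor. Compound 1 (`C#Cc1cccc(NC(=O)CCc2cccc3c2B(O)OC3)c1`) reads > 100000 nM, and this value is a limit of the assay. Compound 2 (`O=C(CCc1cccc2c1B(O)OC2)Nc1cccc(-c2cccc(F)c2)c1`) gives 37000 nM, and the change of 3-fluorophenyl in place of ethynyl on an aromatic carbon makes an at least 2.7-fold lower number from compound 1 to compound 2 (0.43 log units; beyond the scatter). Compound 3 (`O=C(CCc1cccc2c1B(O)OC2)Nc1cccc(-c2cccc(OC(F)(F)F)c2)c1`) gives 9800 nM, the lower of the two exact numbers, reached by a 3.8-fold lower number from compound 2 to compound 3 (0.58 log units; beyond the scatter).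

Compound 4 (`CC(=O)c1cccc(-c2cccc(NC(=O)CCc3cccc4c3B(O)OC4)c2)c1`) carries acetyl in place of trifluoromethoxy on an aromatic carbon. The measured step that bears most directly on this change is a 3.8-fold lower number from compound 2 to compound 3 (0.58 log units; beyond the scatter), since it is the only one that involves trifluoromethoxy. The earlier step, an at least 2.7-fold lower number from compound 1 to compound 2 (0.43 log units; beyond the scatter), bears on it less, as it exchanged different groups. Among the compounds with values here, no acetyl compound has been measured yet, so the comparison is indirect. Removing the trifluoromethoxy group could undo part of the modest drop seen at that earlier exchange, so a move to a higher number is expected, of similar or smaller size. The estimated change is a 2.4-fold higher number from compound 3 to compound 4 (0.39 log units; beyond the scatter). In this assay the estimate for compound 4 is 24000 nM, with an expected range from 9000 nM to 65000 nM.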

Compound 4, half-maximal inhibitory concentration: 2200 nM
Compound 4: middle estimate off by 11-fold (1.04 log units), on the high side; measured number below the stated range.
By their numbers in this assay, from the lowest: compound 4; then compound 3; then compound 2. At a limit, above all of these: compound 1.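

In this assay, acetyl on this aromatic carbon, meta to a large group, gives a 4.5-fold lower number from compound 3 to compound 4 (0.65 log units; beyond the scatter), so the fall seen from fluoro to trifluoromethoxy does not simply continue with the number of heavy atoms, since acetyl has fewer of them than the trifluoromethoxy it replaces. Measured against the fluoro compound, the same position gives a 17-fold lower number from compound 2 to compound 4 (1.23 log units; beyond the scatter), and against the ethynyl compound it gives an at least 45-fold lower number from compound 1 to compound 4 (1.65 log units; beyond the scatter), so the choice of group at this one place moves the number in this assay further than either earlier step had shown. The last of these steps starts from a limit, not from an exact number: the limit of > 100000 nM in this assay, at which 1 of the 4 values shown sits.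

The compounds shown do not tell whether the carbonyl or the methyl of the acetyl group matters more, and a nitrile, a carboxylic acid or an amine at the same place would help to separate the two. They also leave open whether a longer chain on the carbonyl would lower the number further or raise it again.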